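Shifting a Distal Ring Substituent from Fluoro to Cyano

This account rests on a few compounds, and the source may have more. Where it says the series, first, only, none or still open, it means among the compounds named here.

Measured compounds:
- Compound 1, `N[C@@H](COP(=O)(O)OCCCOC(=O)CCc1ccccc1OCc1cccc(Cc2ccccc2)c1)C(=O)O`: 14.5%
- Compound 2, `Cc1ccccc1Oc1cccc(COc2ccccc2CCC(=O)OCCCOP(=O)(O)OC[C@H](N)C(=O)O)c1`: 20.3%
- Compound 3, `N[C@@H](COP(=O)(O)OCCCOC(=O)CCc1ccccc1OCc1cccc(Oc2ccc(F)cc2)c1)C(=O)O`: 18.7%

All three share one core and differ only at the far end of the chain, on an aromatic carbon. In an assay on cells for agonist activity at probable G-protein coupled receptor 34 (Mus musculus), with a stated time of 1 h (on this read-out lower numbers stand for smaller maximal responses and higher numbers for larger maximal responses), compound 3 stands second of the three numbers; its nearest neighbour is compound 2, with a number 1.6 percentage points lower from compound 2 to compound 3 (within the scatter), and its furthest is compound 1, with a number 4.2 percentage points higher from compound 1 to compound 3 (within the scatter). Every step seen so far is therefore within the scatter, and all three compounds give a small maximal response.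

Compound 4, `N#Cc1ccc(Oc2cccc(COc3ccccc3CCC(=O)OCCCOP(=O)(O)OC[C@H](N)C(=O)O)c2)cc1`, is the next step. Its change from compound 3 is cyano in place of fluoro on an aromatic carbon, sitting on an aromatic carbon of a six-membered aromatic ring of carbon only, para to a large group. Among the measured compounds shown here, the one measured step that also alters this outer ring, a number 1.6 percentage points lower from compound 2 to compound 3 (within the scatter), was within the scatter, as was a number 5.8 percentage points higher from compound 1 to compound 2 (within the scatter). No change at this position has moved this assay beyond its scatter, so no step beyond it is expected here: for compound 4 the expected change is a number 0.3 percentage points higher from compound 3 to compound 4 (within the scatter). Compound 4 is accordingly estimated to give 19% in this assay, between 10% and 30%.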

Compound 4, largest response reached (Emax), in percent of the reference or control that the assay uses: 18.3%
Estimate against measurement, compound 4: 0.7 percentage points above; low and high end bracket the measured number.
By their numbers in this assay, from the lowest: compounds 1, 4, 3 and 2 (each within the scatter of the next).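

In this assay, among the compounds shown here, the earlier compounds varied the whole outer group, whereas compound 4 changes a single substituent on that ring: cyano, which brings one hydrogen-bond acceptor that fluoro lacks, gives a number 0.4 percentage points lower from compound 3 to compound 4 (within the scatter). The comparisons with the other outer groups agree, with a number 2 percentage points lower from compound 2 to compound 4 (within the scatter) and a number 3.8 percentage points higher from compound 1 to compound 4 (within the scatter), so all four compounds still give a small maximal response and this position has yet to show a step beyond the scatter. Nothing available explains why swapping fluoro for cyano leaves the read-out in the same range.

The compounds shown leave open whether an amine or a carboxylic acid on this aromatic carbon would move the response beyond the scatter. They also leave open whether a longer chain in place of the cyano would do so.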